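Amine series: a methyl added at the chain carbon

The source may report more compounds than this note shows. Statements on the series, on what has been measured and on what is new or still open speak of the compounds shown alone.

The series is read in an assay on isolated protein for inhibition of Amine oxidase [flavin-containing] A (Rattus norvegicus); on this read-out lower numbers stand for stronger inhibition and higher numbers for weaker inhibition. Compound 1 `CCNCc1cn(Cc2ccccc2)c2ccccc12` gives 262000 nM in this assay. Compound 2 `C#CCN(C)Cc1cc2ccccc2n1C` gives 0.3 nM, and compound 3 `CC#CCN(C)Cc1cc2ccccc2n1C` gives 4.3 nM. Going by the values given here, the difference between the core of compound 1 and that of compound 2 is not broken down here; their values show only that compound 1 sits far above both of the other two. From compound 2 to compound 3 the change is methyl in place of hydrogen on a triple-bonded carbon, and it brought a 14-fold higher number from compound 2 to compound 3 (1.16 log units; beyond the scatter).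

Compound 4 `CC(C)NCc1cn(Cc2ccccc2)c2ccccc12` has not yet been measured. From compound 1 to compound 4 the change is methyl in place of hydrogen on a saturated chain carbon bound to an amine nitrogen and a saturated chain carbon. Among the compounds with values here, this is the same kind of change as the one in the measured pair, not the same change: there the place was on a triple-bonded carbon whose other neighbour is a triple-bonded carbon, here it is on a saturated chain carbon bound to an amine nitrogen and a saturated chain carbon. The expected step from compound 1 to compound 4 is a 1.5-fold higher number from compound 1 to compound 4 (0.18 log units; within the scatter), a slight loss, and it rests with reduced weight on a 14-fold higher number from compound 2 to compound 3 (1.16 log units; beyond the scatter). The weight is reduced: the place of the change differs between the two pairs. For compound 4 the estimate is 400000 nM, expected to fall between 120000 nM and 1300000 nM.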

Compound 4, inhibition constant: 133000 nM
Beside the measured number, compound 4's estimate is 3.0-fold (0.48 log units) above it; measured number inside the range.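

In this assay, methyl in place of hydrogen on a saturated chain carbon bound to an amine nitrogen and a saturated chain carbon gives a 2.0-fold lower number from compound 1 to compound 4 (0.29 log units; within the scatter), so ethylamino to isopropylamino on the core of compound 1 brings no change that can be told from the scatter. Set beside the methyl step on the triple-bonded carbon, the size of the step does not carry from one core to the other: the same change on two cores in this assay, a 14-fold higher number (1.16 log units; beyond the scatter) from compound 2 to compound 3 and a 2.0-fold lower number (0.29 log units; within the scatter) from compound 1 to compound 4, 28-fold (1.45 log units) apart, beyond the scatter of two such steps. Going by these compounds alone, this does not show whether the core or the place of the methyl accounts for the gap, as the two differ together in these pairs and each core carries only one pair.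

Still open, on these data alone, is how a methyl on a saturated chain carbon would read on the core of compound 2, and how a methyl on a triple-bonded carbon would read on the core of compound 1. Also open, as far as these compounds go, is whether a longer chain or a carboxylic acid in place of the isopropyl group would move the number on the core of compound 1.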